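The compounds below may be only part of what the source reports. "The series", "measured", "known", "first", "only" and "open" are said of these compounds alone.

Compound 1 `CC(C)=CC[C@@H](OC(=O)C1CCOC1)C1=CC(=O)c2c(O)ccc(O)c2C1=O` and compound 2 `CC(C)=CC[C@@H](OC(=O)c1ccco1)C1=CC(=O)c2c(O)ccc(O)c2C1=O` share one core and differ only in the acyl group of an ester. In a functional assay on HeLa cells (Homo sapiens) for cytotoxicity, read by MTT assay (on this read-out lower numbers stand for stronger inhibition and higher numbers for weaker inhibition), compound 1 gives 73500 nM, and in this assay compound 2 gives 80300 nM. Among the compounds with values here, the step of a 1.1-fold higher number from compound 1 to compound 2 (0.04 log units; within the scatter) is the only measured comparison, and it places compound 2 and compound 1 within the scatter of one another, so neither can be called weaker or stronger.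

Compound 3 `CC(=O)OC(C)CO[C@H](CC=C(C)C)C1=CC(=O)c2c(O)ccc(O)c2C1=O` is the next candidate. Its difference from compound 2 is 2-acetoxypropyl in place of (furan-2-yl)carbonyl on an oxygen on a saturated carbon. Here the ester is no longer present: the carbonyl leaves with the ring, and a chain enters on the same oxygen. Within the data shown here, the one measured step concerned only an exchange of one acyl ring for another, so it speaks to the new change only in a broad way, showing that swapping the group on this oxygen left the number essentially unchanged.

On that basis the step of a 1.0-fold lower number from compound 2 to compound 3 (0.00 log units; within the scatter) is expected to stay within the scatter, with no clear direction. Compound 3 is therefore estimated to give 80000 nM, in a range from 30000 nM to 200000 nM.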

Compound 3, half-maximal inhibitory concentration: 40100 nM
Compound 3: middle estimate off by 2.0-fold (0.30 log units), on the high side, within the range that was stated.
By their numbers in this assay, from the lowest: compounds 3, 1 and 2 (each within the scatter of the next).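

In this assay, the step of a 2.0-fold lower number from compound 2 to compound 3 (0.30 log units; within the scatter) and the step of a 1.8-fold lower number from compound 1 to compound 3 (0.26 log units; within the scatter) both stay within the usual scatter, so the 2-acetoxypropyl chain on this oxygen cannot be told apart from either acyl group. The earlier pair only exchanged one ring-bearing acyl group for another, whereas this change removes the ring and the carbonyl attached to this oxygen and puts an open chain in their place, and the number still does not move beyond the scatter, so for these three compounds the presence of a ring in this group makes no readable difference. Nothing available explains why these compounds stay so close.

The group that leaves compound 2 and the group that enters compound 3 match in heavy atoms and hydrogen-bond acceptors, so these compounds say little about a group of quite different size or kind on this oxygen. As far as these compounds go, it remains open whether a free hydroxyl, a plain acetyl, a much longer chain, or a chain ending in an amine or a carboxylic acid would leave the number within the same scatter.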